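The source may report more compounds than this note shows. Statements on the series, on what has been measured and on what is new or still open speak of the compounds shown alone.

Measured in a functional assay on HL-60 cells (Homo sapiens) for cytotoxicity, read by WST assay, with a stated time of 48 h; a higher number here means a weaker inhibitor, a lower number a stronger inhibitor:
- compound 1 `COC[C@H](C)[C@@H](C)C(c1ccc(O)c(OC)c1)c1ccc(O)c(OC)c1` gives 68000 nM
- compound 2 `COC[C@@H](C(C)C)C(c1ccc(O)c(OC)c1)c1ccc(O)c(OC)c1` gives 54000 nM
- compound 3 `COc1cc(C(c2ccc(O)c(OC)c2)[C@H](C)[C@@H](C)CO)ccc1O` gives > 100000 nM, which is a limit and not a number

Compound 3 therefore has no exact number, and its place is the limit of > 100000 nM in this assay, at which 1 of the 3 values shown sits. Compound 4 `COc1cc(C(c2ccc(O)c(OC)c2)[C@H](C)[C@@H](C)CF)ccc1O` differs from it by one change: fluoro in place of hydroxy on a saturated chain carbon, four bonds along the chain from two aromatic carbons. This puts fluoro in place of hydroxy on a saturated chain carbon, four bonds along the chain from two aromatic carbons.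

For the measured compounds named here, no measured step makes this exact swap. The nearest evidence is the step that removes the methyl from the oxygen at this chain end, an at least 1.4-fold higher number from compound 1 to compound 3 (0.16 log units; that floor lies within the scatter). A second step also ends at compound 3 but changes the chain as well: an at least 1.8-fold higher number from compound 2 to compound 3 (0.26 log units; that floor lies within the scatter). Both are only floors, so they offer weak guidance.

Compound 1 shows that this chain without a free hydroxy can give a measurable 68000 nM, so a modest move to a lower number is expected in this assay. The expected change is an at least 1.6-fold lower number from compound 3 to compound 4 (0.22 log units; that floor lies within the scatter), and it may not clear the scatter. For compound 4 the estimated value is 60000 nM, with an expected range from 25000 nM to 120000 nM.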

Compound 4, half-maximal inhibitory concentration: 45000 nM
The estimate for compound 4 lay 1.3-fold (0.12 log units) above the measured number; the range from low to high includes it.
By their numbers in this assay, from the lowest: compounds 4, 2 and 1 (each within the scatter of the next). At a limit, above all of these: compound 3.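

In this assay, for the compounds shown here, fluoro in place of hydroxy on this chain carbon gives the first step in this set that clears the scatter: an at least 2.2-fold lower number from compound 3 to compound 4 (0.34 log units; beyond the scatter). Going by these compounds alone, compound 3, the only compound here with a free hydroxy at this chain end, stands at a limit and not at a number: the limit of > 100000 nM in this assay, at which 1 of the 4 values shown sits. Fluoro and methoxy cannot be told apart at this end, with a 1.5-fold lower number from compound 1 to compound 4 (0.18 log units; within the scatter), and replacing the whole 1-(methoxymethyl)-2-methylpropyl group with 2-(fluoromethyl)-1-methylpropyl also gives no clear change, with a 1.2-fold lower number from compound 2 to compound 4 (0.08 log units; within the scatter).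

The compounds shown leave open what an amine, a carboxylic acid or a longer chain would do at this position. They also leave open how large the step from hydroxy to fluoro really is, since only its floor can be read.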